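Swapping chloro for bromo on compound 3

This account rests on a few compounds, and the source may have more. Where it says the series, first, only, none or still open, it means among the compounds named here.

In a functional assay on MCF7 cells (Homo sapiens) for antiproliferative activity, read by MTT assay, with a stated time of 48 h (a lower number here means a stronger inhibitor, a higher number a weaker inhibitor), compound 3 `COc1ccc(/C=C/C(=O)Nc2nnc(-c3ccc(Cl)cc3)s2)cc1` gives 0.91 ug/mL. Compound 1 `O=C(/C=C/c1ccc(C(F)(F)F)cc1)Nc1nnc(-c2ccc(Br)cc2)s1` gives 1.58 ug/mL and compound 2 `O=C(/C=C/c1ccc(F)cc1)Nc1nnc(-c2ccc(Br)cc2)s1` gives 1.49 ug/mL. These three values all lie within the scatter of one another, so compound 3 cannot be separated from the other two on these numbers.

Compound 4 `COc1ccc(/C=C/C(=O)Nc2nnc(-c3ccc(Br)cc3)s2)cc1` differs from compound 3 at a single place: bromo in place of chloro on an aromatic carbon. It has bromo in place of chloro on an aromatic carbon, para to a large group.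

Among the measured compounds shown here, no measured step covers this exchange directly. For the measured compounds named here, the only step available, a 1.1-fold lower number from compound 1 to compound 2 (0.03 log units; within the scatter), is fluoro in place of trifluoromethyl on an aromatic carbon, a change at a different place in the molecule. It bears on the question only indirectly, showing one substitution that left the number within the scatter. Compound 1 and compound 2 also carry the 4-bromophenyl group that compound 4 gains, and neither value stands apart from that of compound 3 at 0.91 ug/mL.

The expected change, a 1.2-fold higher number from compound 3 to compound 4 (0.08 log units; within the scatter), therefore stays within the scatter, with no shift in either direction anticipated beyond it. For compound 4 the estimated value is 1.1 ug/mL, with an expected range of 0.55 ug/mL to 2.2 ug/mL.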

Compound 4, half-maximal inhibitory concentration: 1.13 ug/mL
The estimate for compound 4 lay 1.0-fold (0.01 log units) below the measured number; low and high end bracket the measured number.
By their numbers in this assay, from the lowest: compounds 3, 4, 2 and 1 (each within the scatter of the next).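

In this assay the exchange of 4-chlorophenyl for 4-bromophenyl now has a measured step of its own (a 1.2-fold higher number from compound 3 to compound 4 (0.09 log units; within the scatter)), so chloro and bromo at this place, on an aromatic carbon of the six-membered ring and para to a large group, cannot be told apart on these numbers. Among the compounds shown here, with the 4-bromophenyl group held fixed, compound 4 also supplies a comparison the earlier compounds lacked, setting methoxy against the two fluorinated groups (a 1.3-fold lower number from compound 2 to compound 4 (0.12 log units; within the scatter); a 1.4-fold lower number from compound 1 to compound 4 (0.15 log units; within the scatter)), and neither step separates methoxy from fluoro or trifluoromethyl. No measurement accompanies these compounds that could account for how close their values lie.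

What the compounds shown leave open is whether anything other than a halogen at the place of the exchange, such as an amine or a carboxylic acid, would move the number beyond the scatter. From the compounds shown here alone, it is equally open whether a hydroxy group or a longer alkoxy chain in place of the methoxy of compound 4 would do so, and whether the same closeness of values would hold on any other cell line.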